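This account rests on a few compounds, and the source may have more. Where it says the series, first, only, none or still open, it means among the compounds named here.

Measured compounds:
- compound 1 `c1cnc2c(c1)CCC[C@@H]2N(CCCN1CCNCC1)Cc1cc2ccccc2cn1`: 17 nM
- compound 2 `c1cnc2c(c1)CCC[C@@H]2N(CCCN1CCNCC1)Cc1nc2ccccc2[nH]1`: 45 nM

Among the compounds with values here, in a functional assay on CCRF-CEM cells for antagonist activity at C-X-C chemokine receptor type 4 (Homo sapiens), read by calcium flux, with stated times of 25 min and 90 s (a lower number here means a stronger inhibitor, a higher number a weaker inhibitor), compound 2 stands at the higher of the two measured numbers, with compound 1 the only neighbour: the step of a 2.6-fold higher number from compound 1 to compound 2 (0.42 log units; beyond the scatter) separates them. Compound 3 `c1cnc2c(c1)CCC[C@@H]2N(CCCN1CCNCC1)Cc1nc2ccccc2s1` has not yet been measured. Its structure differs from compound 2 in one place, (1,3-benzothiazol-2-yl in place of 1H-benzimidazol-2-yl on a saturated chain carbon bound to an amine nitrogen). Within the data shown here, the only measured step, a 2.6-fold higher number from compound 1 to compound 2 (0.42 log units; beyond the scatter), concerns the same position, but it exchanges a different aromatic group, so it does not directly test the swap of a benzimidazole for a benzothiazole; it shows only that replacing the aromatic group at this position moves the number by a modest amount. With that single precedent, a change of similar modest size is expected here, and with no direction supported by data, the number is expected to stay near that of compound 2. Compound 3 is therefore estimated to give about 45 nM in this assay, with a plausible range from 15 nM to 135 nM. This estimate corresponds to an expected step of no change at the digits printed from compound 2 to compound 3 (within the scatter).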

Compound 3, half-maximal inhibitory concentration: 1200 nM
Compound 3: middle estimate off by 27-fold (1.43 log units), on the low side; the measured number lies above the stated range.
By their numbers in this assay, from the lowest: compound 1; then compound 2; then compound 3.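

In this assay this position proves far less forgiving than the earlier pair suggested: exchanging the aromatic group here now gives a 27-fold higher number from compound 2 to compound 3 (1.43 log units; beyond the scatter), where the earlier exchange had moved the number only modestly. The two groups match in size and ring types, with 9 heavy atoms each. One nitrogen gives way to sulfur, and the count of hydrogen-bond donors goes from 1 to 0. Measured against the isoquinolin-3-yl group the gap is wider still, at a 71-fold higher number from compound 1 to compound 3 (1.85 log units; beyond the scatter), yet nothing available here explains why the 1,3-benzothiazol-2-yl group fares so poorly.

From the compounds shown here alone, whether the loss of the donor or the arrival of sulfur matters more stays open; 1,3-benzoxazol-2-yl, with oxygen in place of sulfur, and 1-methyl-1H-benzimidazol-2-yl, with a methyl on the ring nitrogen, would help to separate the two. Going by these compounds, it is also open whether these three groups would keep their order if a longer chain were attached to the amine nitrogen.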